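From trifluoromethoxy to ethoxy: compound 2 and compound 3

The compounds below may be only part of what the source reports. "The series", "measured", "known", "first", "only" and "open" are said of these compounds alone.

In a functional assay on HeLa cells (Homo sapiens) for antiproliferative activity, read by MTT assay, with a stated time of 72 h (a lower number here means a stronger inhibitor, a higher number a weaker inhibitor), compound 1 `COc1cc(-n2ncnc2-c2ccc(C)cc2)cc(OC)c1OC` gives 250 nM as its measured value. Compound 2 `COc1cc(-n2ncnc2-c2ccc(OC(F)(F)F)cc2)cc(OC)c1OC` stands at > 10000 nM in this assay as its result, and this is a limit of the assay, not a number. Compound 3 `CCOc1ccc(-c2ncnn2-c2cc(OC)c(OC)c(OC)c2)cc1` keeps the shared core but carries ethoxy instead of trifluoromethoxy, meaning ethyl in place of trifluoromethyl on an oxygen on an aromatic ring. Among the compounds with values here, one measured step bears on this change: trifluoromethoxy in place of methyl on an aromatic carbon gave an at least 40-fold higher number from compound 1 to compound 2 (1.60 log units; beyond the scatter) in this assay as a large step. With trifluoromethoxy gone, compound 3 is expected to move back toward compound 1 at 250 nM in this assay, so a lower number beyond the scatter is expected. The expected size of this change is an at least 66-fold lower number from compound 2 to compound 3 (1.82 log units; beyond the scatter) as estimated here. For compound 3 the estimated value is 150 nM with an expected range from 15 nM to 3000 nM in this estimate.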

Compound 3, half-maximal inhibitory concentration: 15 nM
The estimate for compound 3 lay 10-fold (1.00 log units) above the measured number, and the stated range covers the measured number.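

On this oxygen on an aromatic ring, the choice of group carries great weight: with ethyl in place of trifluoromethyl, this assay shows an at least 660-fold lower number from compound 2 to compound 3 (2.82 log units; beyond the scatter). Compound 2 sits at a limit of the assay and not at a number, so the full size of that step stays unknown: the limit of > 10000 nM in this assay, at which 1 of the 3 values shown sits.

Within the data shown here, what the earlier compounds did not show is that a change at this place can also improve on compound 1, and this comparison rests on two real numbers: ethoxy in place of methyl gives a 17-fold lower number from compound 1 to compound 3 (1.22 log units; beyond the scatter).

Among these compounds, with only three compounds, it remains unclear whether the oxygen, the ethyl or both together account for the gain over compound 1. On these data alone, it is also open whether a longer chain such as propoxy, or an amine at this place, would keep the strength seen in compound 3.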